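The source may report more compounds than this note shows. Statements on the series, on what has been measured and on what is new or still open speak of the compounds shown alone.

Measured in an in vitro ADME assay on microsomes from liver (Mus musculus) for pharmacokinetics, read by LC-MS, with a stated time of 10 min, tested at 1 uM; on this read-out higher numbers stand for fast clearance and lower numbers for slow clearance:
- compound 1 `COc1ccc(NC(=O)[C@H]2CN(C)C[C@@H]2c2ccc(/C=C/C(=O)Nc3ccccc3N)cc2)cc1`: 54 mL/min/kg
- compound 2 `CN1C[C@H](C(=O)Nc2ccc(C#N)cc2)[C@@H](c2ccc(/C=C/C(=O)Nc3ccccc3N)cc2)C1`: 35 mL/min/kg
- compound 3 `Cc1cccc(NC(=O)[C@H]2CN(C)C[C@@H]2c2ccc(/C=C/C(=O)Nc3ccccc3N)cc2)c1`: 74 mL/min/kg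

Compound 3 gives 74 mL/min/kg, and only compound 2 sits clearly apart from it. Compound 4 `CN1C[C@H](C(=O)Nc2ccc(F)c(Cl)c2)[C@@H](c2ccc(/C=C/C(=O)Nc3ccccc3N)cc2)C1` carries 3-chloro-4-fluorophenyl in place of 3-methylphenyl on an amide-type nitrogen. Two measured steps swap the group on that nitrogen: a 1.4-fold higher number from compound 1 to compound 3 (0.14 log units; within the scatter) stays within the scatter, while a 2.1-fold higher number from compound 2 to compound 3 (0.33 log units; beyond the scatter) lies modestly beyond it. Among the compounds with values here, no measured compound carries chlorine or fluorine, so these steps offer only a rough guide. No step beyond the scatter is therefore expected in this assay, and the expected step is a 1.3-fold lower number from compound 3 to compound 4 (0.13 log units; within the scatter). The estimate for compound 4 is 55 mL/min/kg, with an expected range of 30 mL/min/kg to 100 mL/min/kg.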

Compound 4, clearance: 34 mL/min/kg
Beside the measured number, compound 4's estimate is 1.6-fold (0.21 log units) above it; the measured number falls inside the stated range.
By their numbers in this assay, from the lowest: compounds 4, 2, 1 and 3 (each within the scatter of the next, the first and the last beyond it).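

With 3-chloro-4-fluorophenyl on the amide-type nitrogen, this assay shows a 2.2-fold lower number from compound 3 to compound 4 (0.34 log units; beyond the scatter) and so a second group, after 4-cyanophenyl, stands beyond the scatter from 3-methylphenyl. The other two comparisons read as a 1.0-fold lower number from compound 2 to compound 4 (0.01 log units; within the scatter) and a 1.6-fold lower number from compound 1 to compound 4 (0.20 log units; within the scatter) and both stay within the scatter, so 4-methoxyphenyl separates from neither 3-chloro-4-fluorophenyl nor 3-methylphenyl. No information at hand accounts for this step. Going by these compounds, whether 3-chlorophenyl or 4-fluorophenyl alone would give the same step stays open, as does the reading for a cyclohexyl group or an aminophenyl group on this nitrogen.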